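A few compounds are considered here, and "the series" means these few. Any claim that something is new, unique, unknown or untested is made for them only; others in the source may bear on it.

Compound 3 `CCN(CC)CC(=O)Nc1ccc(-c2nc3cc(C(F)(F)F)ccc3[nH]2)cc1` gives 13000 nM in an ADME assay on MDBK cells (Bos taurus) for cytotoxicity, read by MTT assay, with a stated time of 96 h (on this read-out lower numbers stand for higher toxicity in this test and higher numbers for lower toxicity in this test), the lowest of the two numbers shown; compound 1 `Oc1ccc(-c2nc3cc(C(F)(F)F)ccc3[nH]2)cc1` gives 51000 nM, and the step is a 3.9-fold lower number from compound 1 to compound 3 (0.59 log units; beyond the scatter). Compound 2 `CCC(=O)Nc1ccc(-c2nc3cc(C(F)(F)F)ccc3[nH]2)cc1` returns only a limit, > 100000 nM, which is the limit of > 100000 nM in this assay, at which 1 of the 3 values shown sits. From compound 2 onward the step reads an at least 7.6-fold lower number from compound 2 to compound 3 (0.88 log units; beyond the scatter). Compound 4 `O=C(CN1CCCC1)Nc1ccc(-c2nc3cc(C(F)(F)F)ccc3[nH]2)cc1` carries the change (pyrrolidin-1-yl in place of diethylamino on a saturated chain carbon bound to a carbonyl carbon). Among the compounds with values here, only the step from compound 2 to compound 3 bears on this position, and it introduced the amine that compound 4 keeps in ring-closed form; swapping one tertiary amine for another is therefore expected to give no step beyond the scatter in this assay. Compound 4 is expected to give 13000 nM, between 5000 nM and 35000 nM. For compound 4 that means an expected no change at the digits printed from compound 3 to compound 4 (within the scatter).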

Compound 4, half-maximal cytotoxic concentration: 15000 nM
For compound 4 the middle estimate is 1.2-fold (0.06 log units) below the measured one; the range from low to high includes it.
By their numbers in this assay, from the lowest: compounds 3 and 4 (each within the scatter of the next); then compound 1. At a limit, above all of these: compound 2.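

In this assay the swap of diethylamino for pyrrolidin-1-yl on the saturated chain carbon bound to a carbonyl carbon shows no separable effect (a 1.2-fold higher number from compound 3 to compound 4 (0.06 log units; within the scatter)). The lower number therefore holds for both the open and the ring-closed amine in compounds 3 and 4, as the steps from the other two compounds show (an at least 6.6-fold lower number from compound 2 to compound 4 (0.82 log units; beyond the scatter); a 3.4-fold lower number from compound 1 to compound 4 (0.53 log units; beyond the scatter)). Compound 2 gives a limit, not a number: the limit of > 100000 nM in this assay, at which 1 of the 4 values shown sits.

Open, from the compounds shown here alone, is whether a secondary amine, a morpholin-4-yl group or a carboxylic acid on this carbon would shift the number. Also open, going by these compounds, is what a longer chain carrying the amine would do.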